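A few compounds are considered here, and "the series" means these few. Any claim that something is new, unique, unknown or untested is made for them only; others in the source may bear on it.

In a functional assay on L02 cells (Homo sapiens) for inhibition, read by Griess assay, with stated times of 1 h and 24 h (a higher number here means a weaker inhibitor, a lower number a stronger inhibitor), compound 1 (`CCCCNc1nc(/C=C/c2ccccc2)nc2ccsc12`) gives only a limit, > 1000000 nM. Compound 2 (`Brc1ccc(CNc2nc(/C=C/c3ccccc3)nc3ccsc23)cc1`) also gives only a limit, > 1000000 nM. It therefore stands at the limit of > 1000000 nM in this assay, at which 2 of the 2 values shown sit. Among the compounds with values here, the only measured step is a step that the two limits leave unreadable from compound 1 to compound 2, so it offers no size to carry forward. Compound 3 (`Clc1ccccc1CNc1nc(/C=C/c2ccccc2)nc2ccsc12`) has 2-chlorophenyl in place of 4-bromophenyl on the saturated chain carbon bound to a nitrogen on an aromatic ring: 2-chlorophenyl in place of 4-bromophenyl on a saturated chain carbon bound to a nitrogen on an aromatic ring. No step beyond the scatter is expected in this assay, in either direction, and the estimate is a number no higher from compound 2 to compound 3 (the limit leaves the size open). Compound 3 is expected at 1000000 nM, with an estimated range of 300000 nM to 3000000 nM.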

Compound 3, half-maximal inhibitory concentration: > 1000000 nM
Compound 3: a limit, no number; the forecaster's own chance of this, stated with the estimate: 75%; the middle value lies on the limit itself.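

No step can be read from compound 3 to compound 1 or compound 2, as all three give only limits: the limit of > 1000000 nM in this assay, at which 3 of the 3 values shown sit. The compounds shown leave open how strongly each inhibits in this assay, and whether exchanging propyl, 4-bromophenyl and 2-chlorophenyl matters at all.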